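Swapping the side chain of compound 2

A few compounds are considered here, and "the series" means these few. Any claim that something is new, unique, unknown or untested is made for them only; others in the source may bear on it.

Measured so far in a functional assay on MCF7 cells (Homo sapiens) for antiproliferative activity, read by MTT assay, with a stated time of 24 h (a lower number here means a stronger inhibitor, a higher number a weaker inhibitor), are two compounds:
- compound 1 `CCN(CC)CCNC(=O)C1CC(C(CC)(CC)c2ccc(C#CC(C)(C)O)c(C)c2)=CN1CC` with 3170 nM as its value
- compound 2 `CCN(CC)CCNC(=O)C1CC(C(CC)(CC)c2ccc(C#CC(O)C3CCCCC3)c(C)c2)=CN1CC` with 3070 nM as its value

Compound 2 shares its place with compound 1, their values lying within the scatter of each other. Compound 3 (`CCN(CC)CCNC(=O)C1CC(C(CC)(CC)c2ccc(CCC(O)(CC)CC)c(C)c2)=CN1CC`) differs from compound 2 by a group of 8 heavy atoms (7 carbon, 1 oxygen; no ring) in place of a group of 10 heavy atoms (9 carbon, 1 oxygen; one six-membered non-aromatic ring of carbon only), on an aromatic carbon on that same carbon, with 3-ethyl-3-hydroxypentyl entering and the triple bond leaving. Among the compounds with values here, the only measured guide, a 1.0-fold lower number from compound 1 to compound 2 (0.01 log units; within the scatter) as its size, kept the triple bond, so it bears only partly on this change. The expected change in this assay is a 1.0-fold lower number from compound 2 to compound 3 (0.01 log units; within the scatter) and thus nothing beyond the scatter. Compound 3 is estimated at 3000 nM within a range of 1400 nM to 6500 nM as a cautious span.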

Compound 3, half-maximal inhibitory concentration: 3580 nM
For compound 3 the middle estimate is 1.2-fold (0.08 log units) below the measured one; measured number inside the range.
By their numbers in this assay, from the lowest: compounds 2, 1 and 3 (each within the scatter of the next).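

In this assay, compounds with and without the triple bond at this position sit within the scatter of each other: the saturated 3-ethyl-3-hydroxypentyl chain gives a 1.2-fold higher number from compound 2 to compound 3 (0.07 log units; within the scatter) and also a 1.1-fold higher number from compound 1 to compound 3 (0.05 log units; within the scatter) here. The earlier pair kept the triple bond, so only now is this position seen to tolerate its loss in this assay. No measurement here explains this result. Still open, from the compounds shown here alone, is whether an amine or a carboxylic acid in place of the hydroxyl on this chain would move the number beyond the scatter.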